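The source may hold more compounds than are shown below. What is called first, only, known or untested is meant among the compounds shown, and "the series" means these compounds.

In a functional assay on HCT-15 cells (Homo sapiens) for inhibition, read by sulforhodamine B assay, with a stated time of 48 h (a higher number here means a weaker inhibitor of growth, a lower number a stronger inhibitor of growth), compound 1 `COc1cc(-c2cc(/C=C/C(=O)c3ccc(N)cc3)[nH]n2)cc(OC)c1OC` gives 1370 nM, and compound 2 `COc1ccc(-c2cc(/C=C/C(=O)c3ccc(N)cc3)[nH]n2)cc1OC` gives 1700 nM.

Compound 1 has the lowest number of these two. Among the compounds with values here, the only measured step is a 1.2-fold higher number from compound 1 to compound 2 (0.09 log units; within the scatter), which stays within the scatter. Compound 3 `COc1cc(-c2cc(/C=C/C(=O)c3ccc(F)c(F)c3)[nH]n2)cc(OC)c1OC` differs from compound 1 by 3,4-difluorophenyl in place of 4-aminophenyl on a carbonyl carbon. Within the data shown here, the measured step alters a different part of the molecule, so no measured step bears on this change, and the expected direction is open. Compound 3 is therefore expected to land near compound 1, at an estimated 2000 nM, with a range from 700 nM to 6000 nM, which means an expected step of a 1.5-fold higher number from compound 1 to compound 3 (0.16 log units; within the scatter).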

Compound 3, concentration for 50% growth inhibition: 3010 nM
Estimate against measurement, compound 3: 1.5-fold (0.18 log units) below, within the range that was stated.
By their numbers in this assay, from the lowest: compounds 1, 2 and 3 (each within the scatter of the next, the first and the last beyond it).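

Replacing 4-aminophenyl with 3,4-difluorophenyl on the carbonyl carbon gives a 2.2-fold higher number from compound 1 to compound 3 (0.34 log units; beyond the scatter) in this assay, a modest weakening of growth inhibition. The earlier step, at a methoxy on an aromatic carbon, stayed within the scatter, so this is the first change shown to move the number beyond it. No measurement available here explains the step.

As far as these compounds go, this single swap removes the amino group and adds two fluorines at once, so it remains open which of these matters. A plain phenyl or 4-fluorophenyl group at this place would help separate the two.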